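The source may hold more compounds than are shown below. What is called first, only, known or untested is meant among the compounds shown, and "the series" means these compounds.

Compound 1 `CCN(CC)CCCOc1cc2ncnc(Nc3nc4ccc(C(=O)Nc5c(C)cccc5Cl)cc4s3)c2cc1OC` gives 10600 nM in a functional assay on A549 cells (Homo sapiens) for cytotoxicity, read by WST assay, with a stated time of 72 h; on this read-out higher numbers stand for weaker inhibition and lower numbers for stronger inhibition. Compound 2 `CCN(CC)CCCOc1cc2ncnc(Nc3nc4ccc(C(=O)Nc5c(C)cc(C)cc5C)cc4s3)c2cc1OC` carries 2,4,6-trimethylphenyl in place of 2-chloro-6-methylphenyl on an amide-type nitrogen and gives 5700 nM in this assay, a step of a 1.9-fold lower number from compound 1 to compound 2 (0.27 log units; within the scatter). Compound 3 `COc1cc2c(Nc3nc4ccc(C(=O)Nc5c(C)cccc5Cl)cc4s3)ncnc2cc1OCCCN1CCCCC1` differs from compound 1 in its core by piperidin-1-yl in place of diethylamino on a saturated chain carbon, three bonds along the chain from an oxygen on an aromatic ring. In this assay compound 3 gives 12800 nM, a step of a 1.2-fold higher number from compound 1 to compound 3 (0.08 log units; within the scatter). Compound 4 `COc1cc2c(Nc3nc4ccc(C(=O)Nc5c(C)cc(C)cc5C)cc4s3)ncnc2cc1OCCCN1CCCCC1` has not yet been measured in this assay; it differs from compound 3 by 2,4,6-trimethylphenyl in place of 2-chloro-6-methylphenyl on an amide-type nitrogen, the same change that separates compound 1 from compound 2, made on an amide-type nitrogen in both pairs. The step from compound 3 to compound 4 is expected to be a 1.9-fold lower number from compound 3 to compound 4 (0.27 log units; within the scatter). This expectation rests on compound 1 and compound 2, whose step a 1.9-fold lower number from compound 1 to compound 2 (0.27 log units; within the scatter) came from the same change on an unchanged core. Compound 4 is expected to give 6800 nM in this assay, with an estimated range from 3400 nM to 13500 nM.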

Compound 4, half-maximal inhibitory concentration: 10300 nM
Compound 4: middle estimate off by 1.5-fold (0.18 log units), on the low side, within the range that was stated.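

In this assay, 2,4,6-trimethylphenyl in place of 2-chloro-6-methylphenyl on an amide-type nitrogen gives a 1.2-fold lower number from compound 3 to compound 4 (0.09 log units; within the scatter), and this step agrees with the one seen on the core of compound 1: the same change on two cores in this assay, a 1.9-fold lower number (0.27 log units; within the scatter) from compound 1 to compound 2 and a 1.2-fold lower number (0.09 log units; within the scatter) from compound 3 to compound 4, 1.5-fold (0.18 log units) apart, within the scatter of two such steps Likewise, piperidin-1-yl in place of diethylamino gives a 1.8-fold higher number from compound 2 to compound 4 (0.26 log units; within the scatter), which agrees with the earlier step for that change: the same change on two cores in this assay, a 1.2-fold higher number (0.08 log units; within the scatter) from compound 1 to compound 3 and a 1.8-fold higher number (0.26 log units; within the scatter) from compound 2 to compound 4, 1.5-fold (0.18 log units) apart, within the scatter of two such steps Each change thus carries over between these cores within the scatter, but as every one of these steps also lies within the scatter, this does not show that either change has a real effect of its own or that the agreement extends to other cores.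

From the compounds shown here alone, it remains open whether a morpholine or an N-methylpiperazine at the end of the chain would fit the same picture. The same holds for a longer chain or a methoxy group on the phenyl ring of the amide.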